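This account rests on a few compounds, and the source may have more. Where it says the series, first, only, none or still open, it means among the compounds named here.

Compound 1 `Oc1ccc(-c2cc3ccccc3o2)c2cccnc12` is the starting point. In an ADME assay for permeability, using PAMPA, with a stated time of 10 h, tested at 100 ug/mL (on this read-out lower numbers stand for lower permeability and higher numbers for higher permeability), compound 1 gives 4.3 10^-6 cm/s. Compound 2 `Oc1ccc2cc(-c3ccc(O)c4ncccc34)oc2c1` carries hydroxy in place of hydrogen on an aromatic carbon; in this assay compound 2 gives 15.8 10^-6 cm/s, which is a 3.7-fold higher number from compound 1 to compound 2 (0.57 log units; beyond the scatter). Compound 3 `Oc1c(Cl)cc(-c2cc3ccccc3o2)c2cccnc12` differs from compound 1 by chloro in place of hydrogen on an aromatic carbon; in this assay compound 3 gives 2.6 10^-6 cm/s, and a 1.7-fold lower number from compound 1 to compound 3 (0.22 log units; within the scatter). Compound 4 `Oc1ccc2oc(-c3cc(Cl)c(O)c4ncccc34)cc2c1` has not been measured yet. It differs from compound 3 by hydroxy in place of hydrogen on an aromatic carbon, the same change as between compound 1 and compound 2, at a place described in the same words. Among the measured compounds shown here, the step is expected to be a 3.3-fold higher number from compound 3 to compound 4 (0.51 log units; beyond the scatter), set beside a 3.7-fold higher number from compound 1 to compound 2 (0.57 log units; beyond the scatter), because of a 3.7-fold higher number from compound 1 to compound 2 (0.57 log units; beyond the scatter) as the only measured example of this change. Compound 4 is therefore estimated at 8.5 10^-6 cm/s, with a likely range from 4 10^-6 cm/s to 18 10^-6 cm/s.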

Compound 4, apparent permeability: 21.4 10^-6 cm/s
Compound 4: middle estimate off by 2.5-fold (0.40 log units), on the low side, and the stated range ends below it.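

In this assay, hydroxy in place of hydrogen on an aromatic carbon gives an 8.2-fold higher number from compound 3 to compound 4 (0.92 log units; beyond the scatter). Set beside the earlier case, the two steps point the same way and their sizes do not differ by more than the scatter allows: the same change on two cores in this assay, a 3.7-fold higher number (0.57 log units; beyond the scatter) from compound 1 to compound 2 and an 8.2-fold higher number (0.92 log units; beyond the scatter) from compound 3 to compound 4, 2.2-fold (0.35 log units) apart, within the scatter of two such steps. The change therefore carries from the core of compound 1 to the chloro-bearing core of compound 3, but two pairs cover only these two cores and do not show why the number rises.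

The compounds shown leave open whether an amine or a methoxy group in place of the hydroxy would move the number in the same way. They also leave open whether the step would hold on a core carrying bromo instead of chloro.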